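The compounds below may be only part of what the source reports. "The series", "measured", "known", "first", "only" and "open" are said of these compounds alone.

Measured compounds:
compound 1 `CCCn1c(=O)c2nc(-c3cnn(Cc4cccc(C)c4)c3)[nH]c2n(CCC)c1=O`: 36 nM
compound 2 `CCCn1c(=O)c2c(nc(-n3cc(I)cn3)n2Cc2ccccc2)n(CCC)c1=O`: > 5800 nM

All values come from an in vitro assay on HEK293 cells for displacement of a labelled ligand from adenosine receptor A2b (Homo sapiens); on this read-out higher numbers stand for weaker inhibition and lower numbers for stronger inhibition. Among the compounds with values here, compound 1 gives 36 nM in this assay, and this is the only actual number among the two values shown. Compound 2 is reported at > 5800 nM in this assay, which is a limit of the measurement and not a number (the limit of > 5800 nM in this assay, at which 1 of the 2 values shown sits). Within the data shown here, compound 2 differs from compound 1 in more than one place, so no single step between them can be read off.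

Compound 3 `CCCn1c(=O)c2nc(-c3cnn(Cc4cc(C(F)(F)F)ccc4Cl)c3)[nH]c2n(CCC)c1=O` has not yet been measured. It keeps the shared core of compound 1 and differs in one place: 2-chloro-5-(trifluoromethyl)phenyl in place of 3-methylphenyl on a saturated chain carbon bound to an aromatic nitrogen. Among the measured compounds shown here, no measured pair shows a change of this kind, so there is no direct guide to its size. Compound 3 is expected to give 80 nM in this assay, within 25 nM to 300 nM. The estimated step of a 2.2-fold higher number from compound 1 to compound 3 (0.35 log units; beyond the scatter) is expected to be small, leaning toward weaker inhibition, and may not exceed the usual scatter.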

Compound 3, inhibition constant: 22 nM
Beside the measured number, compound 3's estimate is 3.6-fold (0.56 log units) above it; the whole stated range lies above it.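

In this assay, placing 2-chloro-5-(trifluoromethyl)phenyl in place of 3-methylphenyl on a saturated chain carbon bound to an aromatic nitrogen gives a 1.6-fold lower number from compound 1 to compound 3 (0.21 log units; within the scatter), so this read-out does not separate the two compounds. Within the data shown here, the position thus holds a group of 11 heavy atoms, including fluorine and chlorine, as well as one of 7 carbon atoms, with no step beyond the scatter; until now, only one group at this position could be compared with nothing. Nothing measured here explains why the two groups read alike.

Going by these compounds, whether a benzyl-type group carrying an amine or a carboxylic acid, or a longer chain in place of the ring, would read alike stays open. Compound 2 is reported only as a limit and differs from compound 1 in more than one place, so its steps cannot be read.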